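This account rests on a few compounds, and the source may have more. Where it says the series, first, only, none or still open, it means among the compounds named here.

In a functional assay on HepG2 cells (Homo sapiens) for antiproliferative activity, read by MTT assay, with a stated time of 48 h (a lower number here means a stronger inhibitor of growth, a higher number a weaker inhibitor of growth), compound 1 (`COc1cc(C2CC(c3ccccc3)=NN2C(=O)OCc2ccccc2)cc(OC)c1OC`) gives > 10000 nM, a limit of the assay and not a number. Compound 2 (`COc1cccc(C2=NN(C(=O)OCc3ccccc3)C(c3cc(OC)c(OC)c(OC)c3)C2)c1`) gives > 10000 nM, also a limit. Compound 3 (`CCCOC(=O)N1N=C(c2cccc(O)c2)CC1c1cc(OC)c(OC)c(OC)c1`) gives > 10000 nM, again a limit, so its place in the series has no numerical value. The record so far is the limit of > 10000 nM in this assay, at which 3 of the 3 values shown sit.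

Compound 4 (`COc1cc(C2CC(c3cccc(O)c3)=NN2C(=O)OCc2ccccc2)cc(OC)c1OC`) departs from compound 3 at one place: phenyl in place of ethyl on a saturated chain carbon bound to an oxygen next to a carbonyl group. This turns propoxycarbonyl into benzyloxycarbonyl, the group already carried by compound 1 and compound 2.

For the measured compounds named here, the only measured step is a step that the two limits leave unreadable from compound 1 to compound 2, which is methoxy in place of hydrogen on an aromatic carbon, a different change from this one. It gives no size to carry over. Compound 1 and compound 2 show only that benzyloxycarbonyl has so far appeared with limit values in this assay. A result near the limit is therefore expected, with no firm direction.

The expected change is a step that the limit leaves unreadable from compound 3 to compound 4. For compound 4 the estimated value is 12000 nM. The expected range for compound 4 runs from 3000 nM to 30000 nM.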

Compound 4, concentration for 50% growth inhibition: > 10000 nM
Compound 4: a limit, no number; the forecaster's own chance of this, stated with the estimate: 70%; the middle value is on the limit's open side.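

Compound 4 gives a limit and not a number, like compound 1, compound 2 and compound 3, so no step among these compounds can be read: the limit of > 10000 nM in this assay, at which 4 of the 4 values shown sit. The compounds shown leave open which structural change, if any, would give a measurable value in this assay.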